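From phenylsulfanyl to 2-bromophenoxy on a shared core

The compounds below may be only part of what the source reports. "The series", "measured", "known", "first", "only" and "open" are said of these compounds alone.

Measured so far:
compound 1 (`O=c1cc(-n2cc(CSc3ccccc3)nn2)c2cc(Br)ccc2o1`): 3510 nM
compound 2 (`O=c1cc(-n2cc(COc3ccnc4ccc(Br)cc34)nn2)c2cc(Br)ccc2o1`): 13300 nM

In a functional assay on A549 cells (Homo sapiens) for antiproliferative activity, read by MTT assay, with a stated time of 48 h (a lower number here means a stronger inhibitor, a higher number a weaker inhibitor), compound 1 gives 3510 nM and compound 2 gives 13300 nM, so compound 1 holds the lower of the two numbers, and the gap between them lies beyond the scatter. Compound 3 (`O=c1cc(-n2cc(COc3ccccc3Br)nn2)c2cc(Br)ccc2o1`) keeps the core of compound 1 and carries 2-bromophenoxy in place of phenylsulfanyl on a saturated chain carbon bound to an aromatic carbon. Among the measured compounds shown here, no measured pair isolates this kind of change, so the guidance is indirect. The expectation leans on compound 2 (13300 nM), whose group also joins that chain carbon through oxygen. A moderate move toward a higher number in this assay is therefore expected, an estimated step of a 2.0-fold higher number from compound 1 to compound 3 (0.30 log units; within the scatter) that may not clear the scatter by much. For compound 3 the estimated value is 7000 nM (expected range 2500 nM to 20000 nM).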

Compound 3, half-maximal inhibitory concentration: 8430 nM
Beside the measured number, compound 3's estimate is 1.2-fold (0.08 log units) below it; the range from low to high includes it.
By their numbers in this assay, from the lowest: compound 1; then compounds 3 and 2 (each within the scatter of the next).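

Replacing phenylsulfanyl with 2-bromophenoxy on a saturated chain carbon bound to an aromatic carbon gives, in this assay, a 2.4-fold higher number from compound 1 to compound 3 (0.38 log units; beyond the scatter) and is the first single change shown at this position, which proves sensitive to the exchange, though only modestly. The change replaces sulfur with oxygen and also adds bromine, so the step cannot be assigned to either alteration alone. Nothing available explains the difference in the numbers.

Phenoxy without the bromine or 2-bromophenylsulfanyl on the shared core would separate the two alterations, and the compounds shown include neither group. They also leave open how this position would respond to an amine, a carboxylic acid or a longer chain.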